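The source may report more compounds than this note shows. Statements on the series, on what has been measured and on what is new or still open speak of the compounds shown alone.

Working notes on the series, read in a functional assay on MT4 cells (Homo sapiens) for cytotoxicity, read by MTT assay; on this read-out higher numbers stand for lower toxicity in this test and lower numbers for higher toxicity in this test. Compound 1 (`Cc1c(O)nc(SCc2ccccc2)nc1Cc1c(Cl)cccc1Cl`) gives > 64000 nM, which is a limit and not a number. Compound 2 (`COc1cc(CSc2nc(O)c(C)c(Cc3c(Cl)cccc3Cl)n2)cc(OC)c1`) gives > 55000 nM, also a limit. Compound 3 (`Cc1c(O)nc(SCc2cccc(Cl)c2)nc1Cc1c(Cl)cccc1Cl`) gives > 59000 nM, again a limit. So compound 1 stands among values that are all limits. Compound 4 (`CCCCOc1ccc(CSc2nc(O)c(C)c(Cc3c(Cl)cccc3Cl)n2)cc1`) differs from compound 1 by butoxy in place of hydrogen on an aromatic carbon, with butoxy in place of hydrogen on an aromatic carbon, para to a large group. Within the data shown here, the only measured step bearing on this is a step that the two limits leave unreadable from compound 1 to compound 3, so no size carries over and the expectation stays loose. A modest shift toward lower numbers is expected, and compound 4 may again return only a limit. The expected step is an at least 1.4-fold lower number from compound 1 to compound 4 (0.15 log units; that floor lies within the scatter). For compound 4 the estimated value is 45000 nM, with an expected range of 15000 nM to 80000 nM.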

Compound 4, half-maximal cytotoxic concentration: 3100 nM
Compound 4: the middle estimate sits 15-fold (1.16 log units) above what was measured, outside the stated range (below it).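

In this assay, butoxy in place of hydrogen on an aromatic carbon, para to a large group, gives an at least 20-fold lower number from compound 1 to compound 4 (1.31 log units; beyond the scatter) and so moves the read-out toward higher toxicity in this test. Compound 4 is the only compound shown with a number and not a limit. Among these compounds, the chloro step to compound 3 cannot be read, so this is the first readable change on this ring.

From the compounds shown here alone, whether a shorter propoxy chain, a longer hexyloxy chain or an amine at this place would give a similar shift stays open. The full size of the step also stays open, since compound 1 carries only a limit: the limit of > 64000 nM in this assay, at which 1 of the 4 values shown sits.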